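A new ring group for compound 3

The source may report more compounds than this note shows. Statements on the series, on what has been measured and on what is new or still open speak of the compounds shown alone.

compound 1 `O=S(=O)(c1ccccc1)c1nc2ccccc2nc1N1CCc2ccccc2C1` gives 880 nM
compound 2 `COc1ccc(S(=O)(=O)c2nc3ccccc3nc2N2CCc3ccccc3C2)cc1` gives 3690 nM
compound 3 `O=S(=O)(c1ccc(F)cc1)c1nc2ccccc2nc1N1CCc2ccccc2C1` gives 4080 nM

In a functional assay on HL-60 cells (Homo sapiens) for cytotoxicity, read by MTT assay, with a stated time of 72 h (a higher number here means a weaker inhibitor, a lower number a stronger inhibitor), compound 3 and compound 2 share the high end of these three numbers. The a 1.1-fold higher number from compound 2 to compound 3 (0.04 log units; within the scatter) leaves them level, while a 4.6-fold higher number from compound 1 to compound 3 (0.67 log units; beyond the scatter) sets compound 3 clearly apart from compound 1.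

Compound 4 `O=S(=O)(c1ccc(F)cc1)c1nc2ccccc2nc1N1CCC(O)CC1` keeps the (4-fluorophenyl)sulfonyl group and differs by 4-hydroxypiperidin-1-yl in place of 1,2,3,4-tetrahydroisoquinolin-2-yl on an aromatic carbon as 4-hydroxypiperidin-1-yl takes the place of 1,2,3,4-tetrahydroisoquinolin-2-yl on an aromatic carbon. Among the compounds with values here, no measured step touches that place. Within the data shown here, the only guide is the size of steps made elsewhere on these molecules: methoxy in place of hydrogen gave a 4.2-fold higher number from compound 1 to compound 2 (0.62 log units; beyond the scatter) and fluoro in place of hydrogen gave a 4.6-fold higher number from compound 1 to compound 3 (0.67 log units; beyond the scatter) as modest moves.

Guided by that size, the expected move is a 2.2-fold higher number from compound 3 to compound 4 (0.34 log units; beyond the scatter) in this assay although the direction is a judgement these data cannot settle. The estimate for compound 4 is 9000 nM within an expected range of 2500 nM to 30000 nM at this level of uncertainty.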

Compound 4, half-maximal inhibitory concentration: 1450 nM
Compound 4: middle estimate off by 6.2-fold (0.79 log units), on the high side; the measured number lies below the stated range.
By their numbers in this assay, from the lowest: compounds 1 and 4 (each within the scatter of the next); then compounds 2 and 3 (each within the scatter of the next).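

Within the data shown here, compound 4 is the first change at the place ortho to the (4-fluorophenyl)sulfonyl group, as the earlier compounds differed only on the phenyl ring of the sulfonyl group. In this assay, putting 4-hydroxypiperidin-1-yl in place of 1,2,3,4-tetrahydroisoquinolin-2-yl gives a 2.8-fold lower number from compound 3 to compound 4 (0.45 log units; beyond the scatter), so with this sulfonyl group the six-membered aromatic ring of the group that leaves is not needed to reach the lower number. Nothing measured here explains this step.

The compounds shown leave open whether the step comes from the hydroxy group or from losing that aromatic ring, a question that piperidin-1-yl, with no hydroxy group, would help to separate. On these data alone, it is also open how the same swap reads with the unsubstituted phenylsulfonyl group of compound 1, and how an amine such as piperazin-1-yl reads at this place.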